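Formyl for ethyl on the aryl group of compound 3

This account rests on a few compounds, and the source may have more. Where it says the series, first, only, none or still open, it means among the compounds named here.

Measured compounds:
compound 1 `c1ccc2c(-c3cn4ccnc4c(-c4ccc5ncn(C6CCCCC6)c5c4)n3)cccc2c1` gives 9.08%
compound 2 `c1cn2cc(-c3ccsc3)nc(-c3ccc4ncn(C5CCCCC5)c4c3)c2n1` gives 0.39%
compound 3 `CCc1ccc(-c2cn3ccnc3c(-c3ccc4ncn(Cc5ccccc5)c4c3)n2)cc1` gives 20.9%

In a functional assay on SNB-19 cells (Homo sapiens) for inhibition, read by sulforhodamine B assay, with a stated time of 48 h, tested at 10 uM (a lower number here means less inhibition, a higher number more inhibition at the concentration tested (going by the name of the read-out)), compound 3 stands highest of the three, above compound 1 and compound 2 by steps beyond the scatter. Compound 4 `O=Cc1ccc(-c2cn3ccnc3c(-c3ccc4ncn(Cc5ccccc5)c4c3)n2)cc1` differs from compound 3 by formyl in place of ethyl on an aromatic carbon. Within the data shown here, no measured step changes this position; the only measured step, a number 8.7 percentage points lower from compound 1 to compound 2 (within the scatter), swaps the whole aryl group and lies within the scatter, so it bears on this change only loosely. Without a closer precedent, compound 4 is expected to stay near compound 3, with a step of a number 4.9 percentage points lower from compound 3 to compound 4 (within the scatter) of no clear direction beyond the scatter. The estimate for compound 4 is therefore 16%, ranging from 0% to 35%.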

Compound 4, a percentage reported as inhibition, at one concentration (the size of the read-out at that concentration, not a potency): 14.4%
Beside the measured number, compound 4's estimate is 1.6 percentage points above it; the measured number falls inside the stated range.
By their numbers in this assay, from the lowest: compounds 2, 1, 4 and 3 (each within the scatter of the next, the first and the last beyond it).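

In this assay, formyl in place of ethyl on the aromatic carbon, para to a large group, gives a number 6.5 percentage points lower from compound 3 to compound 4 (within the scatter). Among these compounds, this is the first measured change at this position, and it shows that exchanging 4-ethylphenyl for 4-formylphenyl, which adds a hydrogen-bond acceptor to the count, does not move the read-out beyond the scatter. No measurement at hand accounts for this result. Going by these compounds, whether an amine, a carboxylic acid or a longer chain here would shift the number beyond the scatter stays open. A single tested concentration also leaves any difference in potency between compound 3 and compound 4 unresolved.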